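The compounds below may be only part of what the source reports. "The series", "measured", "known", "first", "only" and "open" are said of these compounds alone.

Compound 1 `Cc1ccccc1-c1cc(C(=O)N2CCC3(CC2)CC(=O)c2nn(C(C)(C)C)cc2O3)c2ccccc2n1` is the starting point of this step. In a functional assay on HepG2 cells (Homo sapiens) for inhibition, read by MTT assay, with a stated time of 72 h (on this read-out higher numbers stand for weaker inhibition and lower numbers for stronger inhibition), compound 1 gives > 10000 nM, which is a limit of the assay rather than a measured number, so where compound 1 truly stands is known only as a range (the limit of > 10000 nM in this assay, at which 1 of the 3 values shown sits). Two measured neighbours change the same position on the shared core. Compound 2 `CC(C)(C)n1cc2c(n1)C(=O)CC1(CCN(C(=O)c3cc(-c4ccc(Cl)cc4)nc4ccccc34)CC1)O2` carries 4-chlorophenyl in place of 2-methylphenyl on an aromatic carbon, and in this assay compound 2 gives 630 nM; the step is an at least 15-fold lower number from compound 1 to compound 2 (1.20 log units; beyond the scatter). Compound 3 `CC(C)(C)n1cc2c(n1)C(=O)CC1(CCN(C(=O)c3cc(-c4ccc(N)cc4)nc4ccccc34)CC1)O2` carries 4-aminophenyl in place of 2-methylphenyl, and in this assay compound 3 gives 630 nM; the step is an at least 15-fold lower number from compound 1 to compound 3 (1.20 log units; beyond the scatter). Between the two, amino in place of chloro leaves the read-out unchanged: no change at the digits printed from compound 2 to compound 3 (within the scatter).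

Compound 4 `CC(C)Oc1cc(C(=O)N2CCC3(CC2)CC(=O)c2nn(C(C)(C)C)cc2O3)c2ccccc2n1` differs from compound 1 as follows: isopropoxy in place of 2-methylphenyl on an aromatic carbon. Going by the values given here, no measured compound carries isopropoxy at this position, so the two measured steps, both from 2-methylphenyl to another ring, bear only loosely on this change. The expectation is that compound 4 stays toward the weak end, with a step of an at least 1.2-fold lower number from compound 1 to compound 4 (0.09 log units; that floor lies within the scatter) estimated from the limit of compound 1 > 10000 nM. Compound 4 is therefore estimated at 8000 nM in this assay, within a range from 1500 nM to 30000 nM.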

Compound 4, half-maximal inhibitory concentration: 3150 nM
Compound 4: middle estimate off by 2.5-fold (0.40 log units), on the high side; low and high end bracket the measured number.
By their numbers in this assay, from the lowest: compounds 2 and 3 (each within the scatter of the next); then compound 4. At a limit, above all of these: compound 1.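

In this assay, a group with no ring at this position still gives a measured number, with isopropoxy in place of 2-methylphenyl producing an at least 3.1-fold lower number from compound 1 to compound 4 (0.50 log units; beyond the scatter) and thus a real gain over compound 1. The size of that step is only a floor, because compound 1 stands at a limit of the assay and not at a measured number: the limit of > 10000 nM in this assay, at which 1 of the 4 values shown sits. A ring is therefore not required for a measured number here, yet isopropoxy does not match the two best groups so far, giving a 5.0-fold higher number from compound 3 to compound 4 (0.70 log units; beyond the scatter) and a 5.0-fold higher number from compound 2 to compound 4 (0.70 log units; beyond the scatter), so that 4-aminophenyl and 4-chlorophenyl stay ahead of isopropoxy, with 2-methylphenyl behind all three.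

As far as these compounds go, the position of a plain phenyl remains open, and it would help separate the effect of the ring itself from that of the methyl group on it in compound 1. Also open, from the compounds shown here alone, is how methoxy, a longer ether chain or an amine such as dimethylamino would compare with isopropoxy at this same carbon on the shared core.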